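The source may hold more compounds than are shown below. What is called first, only, known or untested is meant among the compounds shown, and "the series" means these compounds.

Compound 1 `COc1ccc(CN(C(=O)CSc2nc3ccccc3s2)c2cc(OC)c(OC)c(OC)c2)cc1O` gives 35 nM in a functional assay on MGC-803 cells (Homo sapiens) for antiproliferative activity, read by MTT assay, with a stated time of 48 h; on this read-out lower numbers stand for stronger inhibition and higher numbers for weaker inhibition. Compound 2 `COc1cc(N(Cc2ccc(Cl)cc2)C(=O)CSc2nc3ccccc3s2)cc(OC)c1OC` returns only the limit > 80000 nM in this assay, so compound 2 stands at the top of the numbers seen (the limit of > 80000 nM in this assay, at which 1 of the 2 values shown sits). The step of an at least 2200-fold higher number from compound 1 to compound 2 (3.35 log units; beyond the scatter) is the only measured one. Compound 3 `COc1cc(N(Cc2ccc(F)cc2)C(=O)CSc2nc3ccccc3s2)cc(OC)c1OC` differs from compound 2 by fluoro in place of chloro on an aromatic carbon. That measured step concerns the whole aryl group rather than the halogen, so it gives no direct guide to this swap; one halogen for another is expected to shift the number little, by about an at least 1.3-fold lower number from compound 2 to compound 3 (0.12 log units; that floor lies within the scatter). Compound 3 is therefore estimated at 60000 nM, within 8000 nM to 300000 nM.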

Compound 3, half-maximal inhibitory concentration: > 80000 nM
Compound 3 was reported as a limit (the forecaster's own chance of this, stated with the estimate: 65%); at least 1.3-fold (0.12 log units) between middle value and limit.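

In this assay, 4-fluorophenyl gives an at least 2200-fold higher number from compound 1 to compound 3 (3.35 log units; beyond the scatter), so the loss seen with 4-chlorophenyl at this position is not confined to chloro. The step between the two halogen compounds cannot be read, and the reading for compound 3 is a limit, not a number. Both halogen compounds now sit at the same ceiling: the limit of > 80000 nM in this assay, at which 2 of the 3 values shown sit.

Still open, on these data alone, is whether the low number of compound 1 depends on the hydroxy group, the methoxy group or both in 3-hydroxy-4-methoxyphenyl. Also open, as far as these compounds go, is how a 3-hydroxyphenyl, 4-methoxyphenyl or 4-aminophenyl group would read at this position.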